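Acylguanidine series: aryl-to-alkylthio swap at the sulfone-flanked position

This account rests on a few compounds, and the source may have more. Where it says the series, first, only, none or still open, it means among the compounds named here.

The shared core carries a methylsulfonyl group and an acylguanidine, and only the substituent on one aromatic carbon varies. Compound 1 `CCC(C)c1cc(C)c(C(=O)N=C(N)N)cc1S(C)(=O)=O` gives 8 nM in a functional assay for inhibition of sodium/hydrogen exchanger (Oryctolagus cuniculus); on this read-out higher numbers stand for weaker inhibition and lower numbers for stronger inhibition. Compound 2 `CCCCCc1cc(C)c(C(=O)N=C(N)N)cc1S(C)(=O)=O` gives 27 nM in this assay, and compound 3 `Cc1cc(-c2ccc(F)cc2)c(S(C)(=O)=O)cc1C(=O)N=C(N)N` gives 36 nM. Compound 3 sits at the top of the three numbers: the gap from compound 1 is a 4.5-fold higher number from compound 1 to compound 3 (0.65 log units; beyond the scatter), whereas the gap from compound 2 is only a 1.3-fold higher number from compound 2 to compound 3 (0.12 log units; within the scatter), which stays within the scatter. Compound 4 `Cc1cc(SC(C)C)c(S(C)(=O)=O)cc1C(=O)N=C(N)N` is not yet measured; it differs from compound 3 by isopropylsulfanyl in place of 4-fluorophenyl on an aromatic carbon.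

For the measured compounds named here, two measured steps bear on this change. The step of a 3.4-fold higher number from compound 1 to compound 2 (0.53 log units; beyond the scatter) and the step of a 4.5-fold higher number from compound 1 to compound 3 (0.65 log units; beyond the scatter) both show that the branched four-heavy-atom sec-butyl of compound 1 gives the lowest number, while pentyl and 4-fluorophenyl behave alike. Isopropylsulfanyl is again a branched group of four heavy atoms, so a modest lowering is expected, a 2.6-fold lower number from compound 3 to compound 4 (0.41 log units; beyond the scatter). The estimate for compound 4 is therefore 14 nM, with a range from 5 nM to 45 nM.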

Compound 4, half-maximal inhibitory concentration: 12 nM
The estimate for compound 4 lay 1.2-fold (0.07 log units) above the measured number; the measured number falls inside the stated range.
By their numbers in this assay, from the lowest: compounds 1 and 4 (each within the scatter of the next); then compounds 2 and 3 (each within the scatter of the next).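

In this assay, the change at this carbon, ortho to a methylsulfonyl group, gives a 3.0-fold lower number from compound 3 to compound 4 (0.48 log units; beyond the scatter), and replacing pentyl gives a 2.3-fold lower number from compound 2 to compound 4 (0.35 log units; beyond the scatter), so isopropylsulfanyl separates from both groups that had stood apart from sec-butyl. Against sec-butyl itself the step is a 1.5-fold higher number from compound 1 to compound 4 (0.18 log units; within the scatter), which places the two branched groups together, below pentyl and 4-fluorophenyl across these four compounds, with no compound going against this grouping, and shows that a sulfur atom can enter at this carbon without a step beyond the scatter from compound 1. Nothing available explains why these groups sort in this way.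

Open, going by these compounds, is whether an isopropoxy group or a dimethylamino group at this carbon would fall with the two branched groups. Also open, on these data alone, is whether a straight propylsulfanyl chain would stay with them or move toward pentyl, which would separate the branching from the sulfur.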